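Dibromo analogue in the amide series: outlook in this assay

The compounds below may be only part of what the source reports. "The series", "measured", "known", "first", "only" and "open" are said of these compounds alone.

Compound 2 `O=C(COc1ccc2cc(/C=C3/SC(=O)NC3=O)ccc2c1)Nc1ccccc1` stands second highest of the three numbers measured in an assay on isolated protein for inhibition of histone deacetylase 4 (Homo sapiens), with a stated time of 1 h (on this read-out higher numbers stand for weaker inhibition and lower numbers for stronger inhibition), where compound 2 gives 2100 nM. Compound 1 `COc1cccc(NC(=O)COc2ccc3cc(/C=C4/SC(=O)NC4=O)ccc3c2)c1` gives 1600 nM in this assay, and compound 3 `O=C(COc1ccc2cc(/C=C3/SC(=O)NC3=O)ccc2c1)Nc1ccc(Cl)c(Cl)c1` gives 5500 nM. The step of a 1.3-fold higher number from compound 1 to compound 2 (0.12 log units; within the scatter) lies within the scatter, while a 2.6-fold higher number from compound 2 to compound 3 (0.42 log units; beyond the scatter) and a 3.4-fold higher number from compound 1 to compound 3 (0.54 log units; beyond the scatter) lie beyond it, both modest.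

Compound 4 `O=C(COc1ccc2cc(/C=C3/SC(=O)NC3=O)ccc2c1)Nc1ccc(Br)c(Br)c1` has not yet been measured in this assay. Its difference from compound 2: 3,4-dibromophenyl in place of phenyl on an amide-type nitrogen. The measured step that bears most directly on it is a 2.6-fold higher number from compound 2 to compound 3 (0.42 log units; beyond the scatter), which exchanges phenyl for 3,4-dichlorophenyl on the same amide-type nitrogen; a 3.4-fold higher number from compound 1 to compound 3 (0.54 log units; beyond the scatter) points the same way. Nothing measured separates chloro from bromo at these positions, so the dichloro step is taken as the guide. The expected step is therefore modest and toward a higher number: a 2.9-fold higher number from compound 2 to compound 4 (0.46 log units; beyond the scatter). Compound 4 is estimated at 6000 nM in this assay, within a range of 2500 nM to 14000 nM.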

Compound 4, half-maximal inhibitory concentration: 4900 nM
Compound 4: the middle estimate sits 1.2-fold (0.09 log units) above what was measured, and the stated range covers the measured number.
By their numbers in this assay, from the lowest: compounds 1 and 2 (each within the scatter of the next); then compounds 4 and 3 (each within the scatter of the next).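

In this assay, the 3,4-dibromophenyl group on the amide-type nitrogen gives a second halogenated case above phenyl (a 2.3-fold higher number from compound 2 to compound 4 (0.37 log units; beyond the scatter)) and above 3-methoxyphenyl (a 3.1-fold higher number from compound 1 to compound 4 (0.49 log units; beyond the scatter)), so the shift seen with 3,4-dichlorophenyl does not rest on compound 3 alone. Exchanging the two chlorines for two bromines leaves the number within the scatter (a 1.1-fold lower number from compound 3 to compound 4 (0.05 log units; within the scatter)), so this position does not distinguish these two halogens in the compounds shown. No accompanying measurement bears on why these steps take this direction and size.

Still open, going by these compounds, is whether a single chlorine or bromine on the phenyl ring would give the same step as the pair. Also open, on these data alone, is how the same position would read with an amine or a carboxylic acid on that ring in place of the halogens.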